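The source may report more compounds than this note shows. Statements on the series, on what has been measured and on what is new or still open speak of the compounds shown alone.

Measured so far in an ADME assay on Caco-2 cells (Homo sapiens) for permeability, read by LC-MS, in the apical to basolateral direction, with a stated time of 60 min, at pH 6.5 (on this read-out lower numbers stand for lower permeability and higher numbers for higher permeability), are three compounds.
- compound 1 `CC(C)(C)[C@@H](O)C(=O)N1CCS[C@H]1C(=O)NCc1cc(Cl)ccc1-n1cnnn1` gives 5.2 10^-6 cm/s
- compound 2 `O=C(NCc1cc(Cl)ccc1-n1cnnn1)[C@@H]1C[C@@H]2C[C@@H]2N1C(=O)[C@H](O)Cn1cccn1` gives 0.45 10^-6 cm/s
- compound 3 `O=C(NCc1cc(Cl)ccc1-n1cnnn1)[C@@H]1C[C@H]2C[C@H]2N1C(=O)[C@H](O)CC1CC1` gives 6.9 10^-6 cm/s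

Compound 2 stands lowest of the three, and its gaps to compound 1 and compound 3 both lie beyond the usual scatter of repeat measurements. It is also the only one of the three that carries (1H-pyrazol-1-yl)methyl. Compound 4 `O=C(NCc1cc(Cl)ccc1-n1cnnn1)[C@@H]1C[C@@H]2C[C@@H]2N1C(=O)[C@H](O)c1ccccc1F` has not been measured yet. It differs from compound 2 by one change, 2-fluorophenyl in place of (1H-pyrazol-1-yl)methyl on a saturated chain carbon bound to a carbonyl carbon and an oxygen on a saturated carbon and nothing else. Among the measured compounds shown here, no measured pair differs in only one place, so the evidence is indirect. Compound 1 (5.2 10^-6 cm/s) and compound 3 (6.9 10^-6 cm/s) lack that group, although they also differ from compound 2 elsewhere. In this assay a rise is therefore expected, and the estimated 11-fold higher number from compound 2 to compound 4 (1.05 log units; beyond the scatter) would lie beyond the scatter. Compound 4 is expected at 5 10^-6 cm/s (estimated range 2 10^-6 cm/s to 12 10^-6 cm/s).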

Compound 4, apparent permeability: 16 10^-6 cm/s
Beside the measured number, compound 4's estimate is 3.2-fold (0.51 log units) below it; the whole stated range lies below it.
By their numbers in this assay, from the lowest: compound 2; then compounds 1 and 3 (each within the scatter of the next); then compound 4.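

In this assay, among the compounds shown here, putting 2-fluorophenyl in place of (1H-pyrazol-1-yl)methyl shows a 36-fold higher number from compound 2 to compound 4 (1.55 log units; beyond the scatter) and is the first comparison here in which only one place differs. The earlier compounds shown here also differed from compound 2 elsewhere, whereas this pair ties a large change to this one position, on a saturated chain carbon bound to a carbonyl carbon and an oxygen on a saturated carbon. The change replaces a five-membered aromatic ring with 2 hetero atoms by a six-membered aromatic ring of carbon only and adds a fluorine, and nothing available shows which part of that exchange accounts for the step.

As far as these compounds go, it remains open how an unsubstituted phenyl would read at this position, which would test the role of the fluorine. Also open, from the compounds shown here alone, are how an amine or a carboxylic acid on the same carbon would read, and whether the same exchange would give a similar step on the cores of compound 1 and compound 3.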